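From diisopropylamino to piperidin-1-yl: an expected gain

A few compounds are considered here, and "the series" means these few. Any claim that something is new, unique, unknown or untested is made for them only; others in the source may bear on it.

Compound 1 `O=[N+]([O-])c1ccc(/C=C/c2nc(NCCN3CCCCC3)c3ccccc3n2)cc1` gives 28200 nM as a measured value
Compound 2 `CC(C)N(CCNc1nc(/C=C/c2ccc([N+](=O)[O-])cc2)nc2ccc(Cl)cc12)C(C)C` gives > 100000 nM as a limit

Both results come from a functional assay on A549 cells (Homo sapiens) for cytotoxicity, read by MTT assay, with stated times of 48 h and 4 h (a lower number here means a stronger inhibitor, a higher number a weaker inhibitor), and are all that has been measured so far. In this assay compound 2 gives > 100000 nM, which is a limit of the assay and not a number.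

Compound 3 `O=[N+]([O-])c1ccc(/C=C/c2nc(NCCN3CCCCC3)c3cc(Cl)ccc3n2)cc1` has not yet been measured. It differs from compound 2 in one place (piperidin-1-yl in place of diisopropylamino on a saturated chain carbon, two bonds along the chain from a nitrogen on an aromatic ring), with piperidin-1-yl in place of diisopropylamino on a saturated chain carbon, two bonds along the chain from a nitrogen on an aromatic ring. Within the data shown here, no measured pair shows this change alone, so any forecast is rough. The best guide is compound 1, which also carries piperidin-1-yl and gives 28200 nM in this assay as a real number. On that basis, the expected change is an at least 2.8-fold lower number from compound 2 to compound 3 (0.45 log units; beyond the scatter), an estimated move towards stronger inhibition, though its true size is uncertain. For compound 3 the estimate is 35000 nM, with an expected range from 12000 nM to 100000 nM in this test.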

Compound 3, half-maximal inhibitory concentration: 41100 nM
Compound 3: middle estimate off by 1.2-fold (0.07 log units), on the low side, within the range that was stated.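

Among these compounds, for the first time a pair shows this change alone: in this assay, piperidin-1-yl in place of diisopropylamino on a saturated chain carbon, two bonds along the chain from a nitrogen on an aromatic ring, gives an at least 2.4-fold lower number from compound 2 to compound 3 (0.38 log units; beyond the scatter). Among the compounds shown here, the true size of this step remains unknown, because the result for compound 2 is a limit of the assay and not a number: the limit of > 100000 nM in this assay, at which 1 of the 3 values shown sits. The chloro group can also be read for the first time, as chloro in place of hydrogen on an aromatic carbon gives a 1.5-fold higher number from compound 1 to compound 3 (0.16 log units; within the scatter), so with piperidin-1-yl on the chain, this step stays within the usual scatter of this assay.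

The compounds shown leave open whether the ring matters or whether other amines on this chain would serve as well, and pyrrolidin-1-yl, morpholin-4-yl and open-chain diethylamino would help to separate those possibilities. They also leave open how diisopropylamino behaves on the core without chloro, and what a longer chain between the aromatic nitrogen and piperidin-1-yl would do.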